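The compounds below may be only part of what the source reports. "The series", "measured", "known", "first", "only" and "open" are said of these compounds alone.

Working notes on the series. In an ADME assay on a cell-free system (plasma, Rattus norvegicus) for protein binding (a higher number here means a larger unbound share of the compound, a lower number a smaller unbound share), compound 1 (`COc1ccccc1C1CCN(c2ccn3c(CC4CC4)nnc3c2Cl)CC1`) gives < 0.01, which is a limit and not a number. Compound 2 (`COc1c(F)ccc(F)c1C1CCN(c2ccn3c(CC4CC4)nnc3c2Cl)CC1`) gives < 0.01, again a limit, so its position is known only as the limit of < 0.01 in this assay, at which 2 of the 2 values shown sit. Compound 3 (`COc1cc(F)cc(F)c1C1CCN(c2ccn3c(CC4CC4)nnc3c2Cl)CC1`) differs from compound 2 by 2,4-difluoro-6-methoxyphenyl in place of 3,6-difluoro-2-methoxyphenyl on a saturated ring carbon. For the measured compounds named here, the only measured step is a step that the two limits leave unreadable from compound 1 to compound 2, and it offers no size to carry over. No change beyond the scatter is expected, and the estimated step is a step that the limit leaves unreadable from compound 2 to compound 3. Compound 3 is expected at 0.006, with an estimated range from 0.003 to 0.012.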

Compound 3, unbound fraction: < 0.01
Compound 3: only a limit was reported (the forecaster's own chance of this, stated with the estimate: 85%); the middle value is on the limit's open side.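

No new step can be read among compound 1, compound 2 and compound 3 in this assay, as all three values are limits and not numbers: the limit of < 0.01 in this assay, at which 3 of the 3 values shown sit.

The compounds shown leave open how their actual unbound fractions compare, and so whether the difluoro-methoxyphenyl changes make any difference.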